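The source may hold more compounds than are shown below. What is called first, only, known or untested is meant among the compounds shown, and "the series" means these compounds.

Of the compounds shown here, three that share one core have been tested in a functional assay on brain (Rattus norvegicus, strain Wistar) for inhibition; a higher number here means a weaker inhibitor, a lower number a stronger inhibitor. Compound 3 `Cc1[nH]c(=O)n(C)c1-c1ccc(CC(C)C)cc1` gives 7800 nM, and compound 1 `CCCCc1ccc(-c2c(C)[nH]c(=O)n2C)cc1` gives 10700 nM, so these two sit within the scatter of each other. Compound 2 `Cc1ccc(-c2c(C)[nH]c(=O)n2C)cc1` gives 85300 nM and is the weakest of the three.

Compound 4 `CCCCCc1ccc(-c2c(C)[nH]c(=O)n2C)cc1` has not yet been measured. It differs from compound 3 by butyl in place of isopropyl on a saturated chain carbon bound to an aromatic carbon, which turns isobutyl into pentyl.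

Going by the values given here, the closest precedent is isopropyl in place of propyl, a 1.4-fold lower number from compound 1 to compound 3 (0.14 log units; within the scatter), a change within the scatter. The large effects came only from the small group of compound 2, seen in an 11-fold lower number from compound 2 to compound 3 (1.04 log units; beyond the scatter) and an 8.0-fold higher number from compound 1 to compound 2 (0.90 log units; beyond the scatter). Among the compounds with values here, no measured compound carries a chain as long as pentyl, so this is an extrapolation.

The expected result is no change beyond the scatter, a 1.1-fold lower number from compound 3 to compound 4 (0.05 log units; within the scatter). For compound 4 the estimated value is 7000 nM, with an expected range from 2800 nM to 18000 nM.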

Compound 4, half-maximal inhibitory concentration: 5900 nM
Estimate against measurement, compound 4: 1.2-fold (0.07 log units) above, within the range that was stated.
By their numbers in this assay, from the lowest: compounds 4, 3 and 1 (each within the scatter of the next); then compound 2.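

In this assay, the step to pentyl brings no change that can be told from the scatter: a 1.3-fold lower number from compound 3 to compound 4 (0.12 log units; within the scatter) and a 1.8-fold lower number from compound 1 to compound 4 (0.26 log units; within the scatter) both stay within it, so straight and branched chains of these sizes cannot be separated at this position. The large gap to the shortest group remains at this new length, with a 14-fold lower number from compound 2 to compound 4 (1.16 log units; beyond the scatter) marking the distance that separates compound 2 from the others. Nothing measured here explains why these chains read alike.

Going by these compounds, it remains open whether the same level would hold for a longer chain such as octyl, or whether it would be lost. A chain ending in an amine or a carboxylic acid, or a cyclohexyl ring in place of the chain, could also give a different result at this position.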